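The source may report more compounds than this note shows. Statements on the series, on what has been measured and on what is new or still open speak of the compounds shown alone.

In an ADME assay on J774 cells (Mus musculus) for antiproliferative activity, with a stated time of 72 h (a lower number here means that less compound is needed, a higher number that more compound is needed for the effect), compound 1 `CCCCc1cc2c(=O)c(-c3ccncc3)c(C)[nH]c2cc1OCCOc1ccccc1` gives 23000 nM and compound 2 `CCCCc1cc2c(=O)c(-c3ccc(Oc4ccc(OC(F)(F)F)cc4)cc3C)c(C)[nH]c2cc1OCCOc1ccccc1` gives 16000 nM, two values within the scatter of each other. Compound 3 `CCCCc1cc2c(=O)c(-c3ccc(C(F)(F)F)cc3F)c(C)[nH]c2cc1OCCOc1ccccc1` carries 2-fluoro-4-(trifluoromethyl)phenyl in place of the pyridin-4-yl of compound 1 on the shared core: 2-fluoro-4-(trifluoromethyl)phenyl in place of pyridin-4-yl on an aromatic carbon. Going by the values given here, no step between measured compounds that differ in one place is available. Compound 2, which also lacks the pyridin-4-yl, stays at 16000 nM, so no change beyond the scatter is expected in this assay. The expected size is a 1.4-fold lower number from compound 1 to compound 3 (0.16 log units; within the scatter). For compound 3 the estimated value is 16000 nM, with an expected range of 6000 nM to 40000 nM.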

Compound 3, half-maximal effective concentration: 19000 nM
For compound 3 the middle estimate is 1.2-fold (0.07 log units) below the measured one, within the range that was stated.
By their numbers in this assay, from the lowest: compounds 2, 3 and 1 (each within the scatter of the next).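

Going by these compounds alone, at this aromatic carbon of the shared core, the first readable step in this assay is a 1.2-fold lower number from compound 1 to compound 3 (0.08 log units; within the scatter), within the scatter. A six-membered aromatic ring with one hetero atom and a larger, fluorinated ring of carbon only therefore give numbers that cannot be told apart here. No measurement at hand accounts for this.

As far as these compounds go, whether an amine or a carboxylic acid on this carbon would give a number beyond the scatter stays open. So does the effect of changes elsewhere on the shared core in this assay.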